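Ester in place of the aryl tail on the piperazine

The source may hold more compounds than are shown below. What is called first, only, known or untested is meant among the compounds shown, and "the series" means these compounds.

Compound 3 `CCN(CC)c1ccc2cc(C(=O)c3ccc(N4CCN(C(=O)CN5CCN(Cc6ccc(C(F)(F)F)cc6)CC5)CC4)cc3)oc2c1` is the shared core bearing a 4-(trifluoromethyl)benzyl on the ring amine. In an ADME assay on L02 cells (Homo sapiens) for cytotoxicity, read by MTT assay, with a stated time of 48 h (on this read-out lower numbers stand for stronger inhibition and higher numbers for weaker inhibition), compound 3 gives 6540 nM, the lowest of the two numbers seen, with compound 2 `CCN(CC)c1ccc2cc(C(=O)c3ccc(N4CCN(C(=O)CN5CCN(S(=O)(=O)c6ccc(F)cc6)CC5)CC4)cc3)oc2c1` nearest at 9240 nM, a gap of a 1.4-fold lower number from compound 2 to compound 3 (0.15 log units; within the scatter). Compound 1 `CCN(CC)c1ccc2cc(C(=O)c3ccc(N4CCN(C(=O)CN5CCNCC5)CC4)cc3)oc2c1` gives > 100000 nM, which is a limit of the assay and not a number. Both steps from that parent are large: an at least 10-fold lower number from compound 1 to compound 2 (1.03 log units; beyond the scatter) and an at least 15-fold lower number from compound 1 to compound 3 (1.18 log units; beyond the scatter), each resting on (the limit of > 100000 nM in this assay, at which 1 of the 3 values shown sits).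

Compound 4 `CCOC(=O)CN1CCN(CC(=O)N2CCN(c3ccc(C(=O)c4cc5ccc(N(CC)CC)cc5o4)cc3)CC2)CC1` differs from compound 3 by ethoxycarbonyl in place of 4-(trifluoromethyl)phenyl on a saturated chain carbon bound to an amine nitrogen in a ring. Within the data shown here, no measured step covers this exchange; what bears on it is that leaving the amine nitrogen bare left compound 1 at its limit, while either aryl-bearing substituent gave a number. Compound 4 keeps a substituent, but a far smaller one without a ring, so a rise in the number toward compound 1 is expected, though not back to the limit. Compound 4 is therefore estimated at 40000 nM, within 12000 nM to 100000 nM. The expected step is a 6.1-fold higher number from compound 3 to compound 4 (0.79 log units; beyond the scatter).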

Compound 4, half-maximal inhibitory concentration: 68700 nM
Estimate against measurement, compound 4: 1.7-fold (0.23 log units) below; the range from low to high includes it.
By their numbers in this assay, from the lowest: compounds 3 and 2 (each within the scatter of the next); then compound 4. At a limit, above all of these: compound 1.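

In this assay, the 4-(trifluoromethyl)phenyl end of the substituent on the ring amine proves to matter, since exchanging it gives an 11-fold higher number from compound 3 to compound 4 (1.02 log units; beyond the scatter). Replacing the (4-fluorophenyl)sulfonyl on the same nitrogen with (ethoxycarbonyl)methyl likewise gives a 7.4-fold higher number from compound 2 to compound 4 (0.87 log units; beyond the scatter), so a substituent there does not by itself bring the number down to the level of compound 2 and compound 3, and the two groups that do so both carry an aromatic ring. Compound 1 stands at a limit and not a number, so the step to the ester reads only as an at least 1.4-fold lower number from compound 1 to compound 4 (0.16 log units; that floor lies within the scatter), and (ethoxycarbonyl)methyl cannot be told apart from hydrogen on this nitrogen: the limit of > 100000 nM in this assay, at which 1 of the 4 values shown sits.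

From the compounds shown here alone, it remains open whether an unsubstituted benzyl on this nitrogen would read like compound 3 or like compound 4. Also open, going by these compounds, is how a carboxylic acid in place of the ethyl ester would read.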